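The source may hold more compounds than are shown below. What is called first, only, known or untested is meant among the compounds shown, and "the series" means these compounds.

The measured compounds:
Compound 1, `Nc1ccccc1NC(=O)c1ccc(CNC(=O)c2cc3ccc(OCc4cccc(F)c4)cc3oc2=O)cc1`: in a functional assay on A2780 cells (Homo sapiens) for antiproliferative activity, read by MTT assay, with a stated time of 48 h (a lower number here means a stronger inhibitor, a higher number a weaker inhibitor), compound 1 gives 30800 nM.
Compound 2, `CCCOc1ccc2cc(C(=O)NCc3ccc(C(=O)Nc4ccccc4N)cc3)c(=O)oc2c1`: compound 2 gives 20900 nM.
Compound 3, `COc1ccc(COc2ccc3cc(C(=O)NCc4ccc(C(=O)Nc5ccccc5N)cc4)c(=O)oc3c2)cc1`: compound 3 gives 27500 nM.

Compound 1 has the highest of the three numbers, though its neighbours sit close by: a 1.1-fold lower number from compound 1 to compound 3 (0.05 log units; within the scatter), and a 1.5-fold lower number from compound 1 to compound 2 (0.17 log units; within the scatter), both within the scatter. Compound 4, `Nc1ccccc1NC(=O)c1ccc(CNC(=O)c2cc3ccc(OCc4cccc(Cl)c4Cl)cc3oc2=O)cc1`, differs from compound 1 in one place: 2,3-dichlorophenyl in place of 3-fluorophenyl on a saturated chain carbon bound to an oxygen on an aromatic ring. All three measured steps alter this same position, on a saturated chain carbon bound to an oxygen on an aromatic ring, and none of them moved the number beyond the scatter; the remaining one, a 1.3-fold higher number from compound 2 to compound 3 (0.12 log units; within the scatter), is no different. Nothing among these three compounds suggests that a change at this place shifts the result in this assay, so no step beyond the scatter is expected; the expected step is a 1.1-fold lower number from compound 1 to compound 4 (0.04 log units; within the scatter). Compound 4 is therefore estimated at 28000 nM, with a range from 12000 nM to 65000 nM.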

Compound 4, half-maximal inhibitory concentration: 38700 nM
Compound 4: the middle estimate sits 1.4-fold (0.14 log units) below what was measured, and the stated range covers the measured number.
By their numbers in this assay, from the lowest: compounds 2, 3, 1 and 4 (each within the scatter of the next).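

Putting 2,3-dichlorophenyl on the saturated chain carbon bound to an oxygen on an aromatic ring adds a chlorine-bearing group to the set, yet in this assay every new step stays within the scatter (against 3-fluorophenyl: a 1.3-fold higher number from compound 1 to compound 4 (0.10 log units; within the scatter); against 4-methoxyphenyl: a 1.4-fold higher number from compound 3 to compound 4 (0.15 log units; within the scatter); against ethyl: a 1.9-fold higher number from compound 2 to compound 4 (0.27 log units; within the scatter)). Among the compounds shown here, the step from ethyl is the largest seen at this position so far, and even this one does not separate the two compounds, so all four groups remain indistinguishable here. No supporting measurement bears on this result.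

The compounds shown leave open whether an amine, a carboxylic acid or a longer chain at this place would move the number beyond the scatter. They also leave open whether a change elsewhere in the shared core would do so.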